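Halophenyl amide variants of a pyridine hydrazone series

The source may hold more compounds than are shown below. What is called first, only, known or untested is meant among the compounds shown, and "the series" means these compounds.

Compound 3 `C/C(=N\NC(=O)c1ccncc1)C(=O)Nc1cccc(Cl)c1` gives only a limit in a functional assay on HepG2 cells (Homo sapiens) for cytotoxicity, read by MTT assay, with a stated time of 72 h (on this read-out lower numbers stand for stronger inhibition and higher numbers for weaker inhibition), namely > 50000 nM. Compound 1 `C/C(=N\NC(=O)c1ccncc1)C(=O)Nc1ccc(F)cc1` likewise reaches only a limit in this assay, > 50000 nM. Compound 2 `C/C(=N\NC(=O)c1ccncc1)C(=O)Nc1ccc(C(F)(F)F)cc1` also stops at a limit in this assay, > 50000 nM. The measured steps a step that the two limits leave unreadable from compound 1 to compound 2 and a step that the two limits leave unreadable from compound 1 to compound 3 thus have no readable size, in line with the limit of > 50000 nM in this assay, at which 3 of the 3 values shown sit. Compound 4 `C/C(=N\NC(=O)c1ccncc1)C(=O)Nc1ccc(Br)cc1` carries 4-bromophenyl in place of 3-chlorophenyl on an amide-type nitrogen. Neither measured step bears on this change in a readable way, so no step beyond the scatter can be drawn from them. Compound 4 is therefore expected to remain at the limit in this assay, with an expected step that the limit leaves unreadable from compound 3 to compound 4 that cannot be read. The estimate for compound 4 is 80000 nM, in the range 30000 nM to 300000 nM.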

Compound 4, half-maximal inhibitory concentration: > 50000 nM
Compound 4: a limit, no number (the forecaster's own chance of this, stated with the estimate: 85%); the middle value does not contradict the limit.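

Among the compounds shown here, compound 4 reaches only a limit in this assay, > 50000 nM, so no step linking it to compound 1, compound 2 or compound 3 can be read: the limit of > 50000 nM in this assay, at which 4 of the 4 values shown sit. The compounds shown leave open which group on the amide-type nitrogen, if any, would give a readable value in this assay.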